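The source may report more compounds than this note shows. Statements on the series, on what has been measured and on what is new or still open speak of the compounds shown alone.

Working notes on the series. Compound 1 `COc1cccc(OC)c1OCCNCCOc1ccccc1OCc1ccccc1` gives 8.39 in a functional assay on Vas deferens for antagonist activity at Alpha-1A adrenergic receptor (Rattus norvegicus) (on this read-out higher numbers stand for higher potency (the scale is a negative logarithm) and lower numbers for lower potency), the highest of the two numbers in hand. Going by the values given here, compound 2 `COc1cccc(OC)c1OCCNCCOc1ccccc1OCc1ccccc1C` gives 7.81 in this assay; the only step measured so far, methyl in place of hydrogen on an aromatic carbon, reads a number 0.58 log units lower from compound 1 to compound 2 (beyond the scatter).

Compound 3 `COc1cccc(OC)c1OCCNCCOc1ccccc1OCc1ccc(OC(C)C)cc1` has not yet been measured in this assay. It differs from compound 1 by isopropoxy in place of hydrogen on an aromatic carbon. Among the compounds with values here, the step from compound 1 to compound 2 is the single measured step that bears on this change, since it also placed a group on an aromatic carbon of the benzyl portion of the molecule; it ran modestly downward, beyond the scatter. That precedent involved a methyl, whereas compound 3 carries an isopropoxy, so the comparison is loose, but no other measurement speaks to the question. A modest step in the lowering direction is therefore expected for compound 3 in this assay, namely a number 0.49 log units lower from compound 1 to compound 3 (beyond the scatter). Compound 3 is accordingly estimated at 7.9, with a range from 7.3 to 8.5.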

Compound 3, negative logarithm of the antagonist equilibrium constant: 8.17
Compound 3: the middle estimate sits 0.27 log units below what was measured; measured number inside the range.
By their numbers in this assay, from the lowest: compound 2; then compounds 3 and 1 (each within the scatter of the next).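

In this assay, going from benzyl to 4-isopropoxybenzyl reads a number 0.22 log units lower from compound 1 to compound 3 (within the scatter), so this place, para to a large group, carries isopropoxy and its 4 heavy atoms with no difference that can be told from repeated measurement. The earlier step, a number 0.58 log units lower from compound 1 to compound 2 (beyond the scatter), therefore does not hold for every group added to this aromatic ring: the lowering seen with 2-methylphenyl does not recur with 4-isopropoxyphenyl. The exchange of one for the other reads a number 0.36 log units higher from compound 2 to compound 3 (beyond the scatter), but it alters both the group and its place on the ring, so it cannot show which of the two accounts for the gap. Nothing in hand gives a reason for these numbers.

The compounds shown leave open whether a methyl in the place held by isopropoxy would read like compound 2 or like compound 3, which would separate the group from its place. Also open, as far as these compounds go, is how an amine or a carboxylic acid on this ring, or a longer alkoxy chain in place of isopropoxy, would read in this assay on the same core.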